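Swapping the Aryl Cap on a Cinnamamide Benzophenone

The source may hold more compounds than are shown below. What is called first, only, known or untested is meant among the compounds shown, and "the series" means these compounds.

Compound 1, `COc1ccc(C(=O)c2cc(OC)c(OC)c(OC)c2)cc1NC(=O)/C=C/c1ccc(F)cc1`: 1800 nM
Compound 2, `C#CCOc1cccc(/C=C/C(=O)Nc2cc(C(=O)c3cc(OC)c(OC)c(OC)c3)cc(OC)c2OC)c1`: 8100 nM

Of the compounds shown here, two have been measured in a functional assay on HT-29 cells (Homo sapiens) for cytotoxicity, read by MTT assay, with a stated time of 72 h; on this read-out higher numbers stand for weaker inhibition and lower numbers for stronger inhibition. Compound 1 gives 1800 nM, and compound 2 gives 8100 nM. Compound 2 therefore stands at the higher of the two numbers, and its gap to compound 1 lies beyond the usual scatter, so compound 2 is the weaker inhibitor of the pair. The two compounds differ both in the aryl cap of the cinnamamide and in the substitution of the shared core, so no single change can be read from them.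

Compound 3, `COc1cc(C(=O)c2cc(OC)c(OC)c(OC)c2)cc(NC(=O)/C=C/c2ccc(F)cc2)c1OC`, keeps the core of compound 2 and changes only the cap: 4-fluorophenyl in place of 3-(propargyloxy)phenyl on a double-bonded chain carbon bound to a double-bonded chain carbon. Compound 3 thus carries the same cap as compound 1. Because compound 1 reaches 1800 nM with that same 4-fluorophenyl group, a step toward stronger inhibition is expected, though the core of compound 2 may hold it back. Compound 3 is expected to give about 3000 nM, within 1000 nM to 9000 nM. This amounts to an estimated step of a 2.7-fold lower number from compound 2 to compound 3 (0.43 log units; beyond the scatter).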

Compound 3, half-maximal inhibitory concentration: 1800 nM
The estimate for compound 3 lay 1.7-fold (0.22 log units) above the measured number; the measured number falls inside the stated range.
By their numbers in this assay, from the lowest: compounds 1 and 3 (each within the scatter of the next); then compound 2.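

With the core of compound 2 held fixed, 4-fluorophenyl in place of 3-(propargyloxy)phenyl on a double-bonded chain carbon bound to a double-bonded chain carbon gives a 4.5-fold lower number from compound 2 to compound 3 (0.65 log units; beyond the scatter) in this assay, so the cap alone can move this number beyond the scatter. With the 4-fluorophenyl cap held fixed, methoxy in place of hydrogen on an aromatic carbon gives no change at the digits printed from compound 1 to compound 3 (within the scatter) in this assay, so this change to the core leaves the number unmoved with this cap. No independent measurement here explains the step at the cap.

The swap replaces a whole group, so the loss of the propargyloxy chain cannot be separated from the arrival of the fluorine. On these data alone, whether a plain phenyl or a 4-aminophenyl cap would group with compound 3 or with compound 2 remains open.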